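Whole-animal activity of a phenylpiperazine series: compound 3 to compound 4

The source may hold more compounds than are shown below. What is called first, only, known or untested is meant among the compounds shown, and "the series" means these compounds.

Of the compounds shown here, three sharing one core have been tested in a functional assay on the whole organism (strain CD-1) with Mus musculus as the target, with a stated time of 2 h; a higher number here means that more compound is needed for the effect, a lower number that less compound is needed. Compound 1, `CC1(c2ccccc2)CC(=O)N(CC(=O)N2CCN(c3ccccc3)CC2)C1=O`, gives 300 mg/kg. Compound 2, `COc1ccccc1N1CCN(C(=O)CN2C(=O)CC(C)(c3ccccc3)C2=O)CC1`, gives "not active" (no number reported), so no single number describes it. Compound 3, `CC1(c2ccccc2)CC(=O)N(CC(=O)N2CCN(c3ccc(F)cc3)CC2)C1=O`, likewise gives "not active" (no number reported), and no number is recorded for it either. Compound 3 therefore stands without a measured dose, alongside compound 2 in the same position; only compound 1 carries a figure.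

Compound 4, `CC1(c2ccccc2)CC(=O)N(CC(=O)N2CCN(c3cccc(C(F)(F)F)c3)CC2)C1=O`, is the next step: 3-(trifluoromethyl)phenyl in place of 4-fluorophenyl on an amine nitrogen in a ring. Going by the values given here, no measured pair in this set isolates such a change, so its direction cannot be read from the data. Given that compound 3 shows "not active" (no number reported) and compound 1 shows 300 mg/kg, compound 4 is expected to fall in a similar region, high doses or no number at all, rather than beyond the scatter in either direction. Compound 4 is estimated at 300 mg/kg, in a range from 100 mg/kg to 1000 mg/kg, with a real chance that only inactivity is reported.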

Compound 4, minimum effective dose: "not active" (no number reported)
No number was reported for compound 4; no gap can be computed for the estimate.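

Compound 3 and compound 4 are both reported as not active in this assay, so no step can be read between them. As far as these compounds go, whether 3-(trifluoromethyl)phenyl and 4-fluorophenyl differ at all in the dose needed stays open. No supporting evidence bears on this result.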